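From Methoxy to Ethoxy on a Shared Core

A few compounds are considered here, and "the series" means these few. Any claim that something is new, unique, unknown or untested is made for them only; others in the source may bear on it.

Compound 1 `COc1c(OC(C)C)cc2occ(-c3csc4ccccc34)c(=O)c2c1OC(C)C` gives > 10000 nM as a limit, not a number
Compound 2 `COc1cc2occ(-c3csc4ccccc34)c(=O)c2c(OC)c1OC` gives 740 nM as a measured number

Within the data shown here, in a functional assay on MCF7 cells (Homo sapiens) for antiproliferative activity, read by sulforhodamine B assay, with a stated time of 72 h (on this read-out higher numbers stand for weaker inhibition and lower numbers for stronger inhibition), compound 2 gives 740 nM as the only true number so far. Compound 1 reports > 10000 nM in this assay and that value is a limit. No single structural change has yet been measured on its own.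

Compound 3 `CCOc1c(OC)cc2occ(-c3csc4ccccc34)c(=O)c2c1OC` alters compound 2 in one place by methyl in place of hydrogen on a saturated chain carbon bound to an oxygen on an aromatic ring and so turns a methoxy into an ethoxy.

Compound 1 and its limit of > 10000 nM give the only hint of direction, so a modest weakening is expected in this assay rather than a gain. This is a cautious expectation, and a result within the usual scatter would fit it as well. The expected size of the change is a 1.6-fold higher number from compound 2 to compound 3 (0.21 log units; within the scatter) in the weakening direction. The estimated value for compound 3 is 1200 nM with an expected range (400 nM to 5000 nM) around it.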

Compound 3, half-maximal inhibitory concentration: 4000 nM
The estimate for compound 3 lay 3.3-fold (0.52 log units) below the measured number; low and high end bracket the measured number.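

In this assay, the shared core now has its first measured single change: a 5.4-fold higher number from compound 2 to compound 3 (0.73 log units; beyond the scatter). This step lies beyond the scatter, so one added methyl, which turns a methoxy into an ethoxy, is enough on its own to weaken the result at this place, on a saturated chain carbon bound to an oxygen on an aromatic ring. Compound 1 could not show this, as it differs from compound 2 in more than one place and gives a limit rather than a number: the limit of > 10000 nM in this assay, at which 1 of the 3 values shown sits.

Compound 3 still gives a true number, so the effect of this small extension has a measured size, but a single step shows neither a trend nor its cause. From the compounds shown here alone, whether a longer chain such as propyl would weaken the result further, whether a hydroxyl or an amine at the end of the chain would reverse the direction, and whether the same methyl addition on either of the other methoxy groups would have a similar effect all remain open.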